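The compounds below may be only part of what the source reports. "The series", "measured", "known", "first", "only" and "open" are said of these compounds alone.

In an assay on HEK293 cells for displacement of a labelled ligand from 5-hydroxytryptamine receptor 6 (Homo sapiens), read by radioligand binding, with a stated time of 1 h; on this read-out higher numbers stand for weaker inhibition and lower numbers for stronger inhibition:
Compound 1 `CN1CCN(c2nc(N)nc(COc3ccccc3)n2)CC1`: 507 nM
Compound 2 `CN1CCN(c2nc(N)nc(COc3ccccc3Cl)n2)CC1`: 129 nM
Compound 3 `CN1CCN(c2nc(N)nc(COc3cccc(Cl)c3)n2)CC1`: 148 nM

Compound 3 stands second highest of these three numbers; its nearest neighbour is compound 2, within the scatter, and the furthest is compound 1. Compound 4 `Cc1ccccc1OCc1nc(N)nc(N2CCN(C)CC2)n1` differs from compound 3 by 2-methylphenyl in place of 3-chlorophenyl on an oxygen on a saturated carbon. Among the compounds with values here, no measured step swaps a chloro for a methyl, so the nearest guides are the two steps that add a chloro, a 3.4-fold lower number from compound 1 to compound 3 (0.53 log units; beyond the scatter) and a 3.9-fold lower number from compound 1 to compound 2 (0.59 log units; beyond the scatter), while a 1.1-fold higher number from compound 2 to compound 3 (0.06 log units; within the scatter). A methyl on that ring has no record here, so the number for compound 4 is expected to fall between the unsubstituted compound 1 and the chloro compounds, a modest rise estimated as a 1.7-fold higher number from compound 3 to compound 4 (0.23 log units; within the scatter). Compound 4 is thus expected to give 250 nM, within a range of 100 nM to 600 nM.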

Compound 4, inhibition constant: 87 nM
Estimate against measurement, compound 4: 2.9-fold (0.46 log units) above; measured number below the stated range.
By their numbers in this assay, from the lowest: compounds 4, 2 and 3 (each within the scatter of the next); then compound 1.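

In this assay the new compound shows that the step from the bare phenyl ring does not depend on chlorine: a 5.8-fold lower number from compound 1 to compound 4 (0.77 log units; beyond the scatter) and this lies beyond the scatter. Methyl and chloro cannot be told apart here, since a 1.5-fold lower number from compound 2 to compound 4 (0.17 log units; within the scatter) and a 1.7-fold lower number from compound 3 to compound 4 (0.23 log units; within the scatter) are both within the scatter. No evidence is available to explain why a methyl and a chloro give such similar numbers.

Still open, as far as these compounds go, is whether an ethyl, a methoxy or a trifluoromethyl on the phenyl ring would give numbers like these in this assay as well.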